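One added methoxy on a compound at the limit

This account rests on a few compounds, and the source may have more. Where it says the series, first, only, none or still open, it means among the compounds named here.

Values in a functional assay on AGS cells (Homo sapiens) for antiproliferative activity, read by MTT assay, with a stated time of 48 h (on this read-out lower numbers stand for stronger inhibition of growth and higher numbers for weaker inhibition of growth), each one a limit of the assay:
Compound 1 `COc1ccc(N(C)c2ncnc3c2ncn3Cc2cc(OC)c(OC)c(OC)c2)cc1`: > 100000 nM
Compound 2 `COc1ccc(Cn2cnc3c(Cl)ncnc32)cc1OC`: > 100000 nM
Compound 3 `COc1cc(Cn2cnc3c(Cl)ncnc32)cc(OC)c1`: > 100000 nM

None of these three entries is a true number, so the compounds cannot be ranked. Compound 3 stands only at a limit, > 100000 nM. The whole set sits at the limit of > 100000 nM in this assay, at which 3 of the 3 values shown sit.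

Compound 4 `COc1cc(Cn2cnc3c(Cl)ncnc32)cc(OC)c1OC` differs from compound 3 by a single change: methoxy in place of hydrogen on an aromatic carbon. A methoxy takes the place of a hydrogen on an aromatic carbon, ortho to two methoxy groups and para to a large group. Among the measured compounds shown here, no measured pair isolates this change. Compound 1 also has a ring with three methoxy groups, and its value is a limit, > 100000 nM. No step beyond the scatter is therefore expected in this assay, and another limit is the likeliest report. The estimated step is a number no higher from compound 3 to compound 4 (the limit leaves the size open). For compound 4 the estimated value is 100000 nM, with an expected range from 30000 nM to 200000 nM.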

Compound 4, concentration for 50% growth inhibition: > 50000 nM
Compound 4: only a limit was reported; the forecaster's own chance of this, stated with the estimate: 75%; the middle value is on the limit's open side.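

In this assay compound 4 gives > 50000 nM, which is a limit of the assay. Among the compounds shown here, all four entries are limits, and no step from compound 1, compound 2 or compound 3 to compound 4 can be read. The compounds shown leave open whether the added methoxy changes growth inhibition at all.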